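Cytotoxicity of an acetylated glycoside series: moving to 3-methylbenzyl

This account rests on a few compounds, and the source may have more. Where it says the series, first, only, none or still open, it means among the compounds named here.

This account follows compound 3 `CC(=O)OC[C@H]1O[C@@H](CC(=O)/C=C2\C(=O)N(Cc3ccc(F)cc3)c3ccccc32)[C@H](OC(C)=O)[C@@H](OC(C)=O)[C@@H]1OC(C)=O` to compound 4 `CC(=O)OC[C@H]1O[C@@H](CC(=O)/C=C2\C(=O)N(Cc3cccc(C)c3)c3ccccc32)[C@H](OC(C)=O)[C@@H](OC(C)=O)[C@@H]1OC(C)=O` in an ADME assay on Vero cells (Chlorocebus sabaeus) for cytotoxicity, read by resazurin assay, with a stated time of 72 h; a higher number here means that more compound is tolerated, a lower number that less compound is tolerated. Compound 1 `CCCCN1C(=O)/C(=C\C(=O)C[C@@H]2O[C@H](COC(C)=O)[C@@H](OC(C)=O)[C@H](OC(C)=O)[C@H]2OC(C)=O)c2ccccc21` gives 126000 nM in this assay, and compound 2 `CC(=O)OC[C@H]1O[C@@H](CC(=O)/C=C2\C(=O)N(Cc3ccc(Br)cc3)c3ccccc32)[C@H](OC(C)=O)[C@@H](OC(C)=O)[C@@H]1OC(C)=O` gives 76500 nM. Compound 3 gives 119000 nM, the second highest of the three numbers, lying nearest to compound 1 and furthest from compound 2, with both gaps inside the scatter.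

The change to compound 4 is 3-methylphenyl in place of 4-fluorophenyl on a saturated chain carbon bound to an amide-type nitrogen in a ring. Within the data shown here, three measured steps touch this position. The step of a 1.1-fold lower number from compound 1 to compound 3 (0.02 log units; within the scatter) and the step of a 1.6-fold lower number from compound 1 to compound 2 (0.22 log units; within the scatter) each replace the propyl group, while a 1.6-fold higher number from compound 2 to compound 3 (0.19 log units; within the scatter) swaps the substituent on the aromatic ring; none of them leaves the scatter. Among the measured compounds shown here, the record therefore shows no step at this position that moves the read-out, and a step beyond the scatter is not expected for compound 4 in this assay.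

Compound 4 is accordingly estimated at 115000 nM, with a range from 60000 nM to 220000 nM, which corresponds to an expected step of a 1.0-fold lower number from compound 3 to compound 4 (0.01 log units; within the scatter).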

Compound 4, half-maximal cytotoxic concentration: 72500 nM
Compound 4: the middle estimate sits 1.6-fold (0.20 log units) above what was measured; measured number inside the range.
By their numbers in this assay, from the lowest: compounds 4, 2, 3 and 1 (each within the scatter of the next).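

In this assay the place on the saturated chain carbon bound to an amide-type nitrogen now also carries a group with a methyl substituent and no halogen, and the read-out stays within the scatter of every earlier compound (a 1.6-fold lower number from compound 3 to compound 4 (0.22 log units; within the scatter); a 1.1-fold lower number from compound 2 to compound 4 (0.02 log units; within the scatter); a 1.7-fold lower number from compound 1 to compound 4 (0.24 log units; within the scatter)). Across the four compounds shown, propyl, 4-bromophenyl, 4-fluorophenyl and 3-methylphenyl thus give numbers that all lie within the scatter of one another, with no compound going against this. Nothing on record explains the small differences that remain.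

The step to compound 4 changes the substituent and its place on the ring together, so the two contributions cannot be told apart. From the compounds shown here alone, how an amine, a carboxylic acid or a longer chain at this place would read remains open.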